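The source may hold more compounds than are shown below. What is called first, only, known or untested is meant among the compounds shown, and "the series" means these compounds.

Working notes on the series in a functional assay on KB cells (Homo sapiens) for cytotoxicity, read by spectrophotometry and crystal violet staining; on this read-out higher numbers stand for weaker inhibition and lower numbers for stronger inhibition. Compound 1 `CC(=O)N/N=C/c1c(Cl)n(C2O[C@H](CO)[C@@H](O)[C@H]2O)c2cc(Cl)c(Cl)cc12` gives 9000 nM. Compound 2 `N/C(=N\O)c1c(Cl)n(C2O[C@H](CO)[C@@H](O)[C@H]2O)c2cc(Cl)c(Cl)cc12` reaches only the limit > 100000 nM. Compound 3 `NC(=O)N/N=C/c1c(Cl)n(C2O[C@H](CO)[C@@H](O)[C@H]2O)c2cc(Cl)c(Cl)cc12` likewise reaches only the limit > 100000 nM, so its standing rests on the limit of > 100000 nM in this assay, at which 2 of the 3 values shown sit, rather than on a number. The steps recorded are an at least 11-fold higher number from compound 1 to compound 2 (1.04 log units; beyond the scatter) and an at least 11-fold higher number from compound 1 to compound 3 (1.04 log units; beyond the scatter), while a step that the two limits leave unreadable from compound 2 to compound 3. Compound 4 `NC(=O)c1c(Cl)n(C2O[C@H](CO)[C@@H](O)[C@H]2O)c2cc(Cl)c(Cl)cc12` differs from compound 3 by a group of 3 heavy atoms (1 carbon, 1 nitrogen, 1 oxygen; no ring) in place of a group of 6 heavy atoms (2 carbon, 3 nitrogen, 1 oxygen; no ring), on an aromatic carbon. Among the compounds with values here, the step most like it in kind, a smaller group on the same aromatic carbon, is an at least 11-fold higher number from compound 1 to compound 2 (1.04 log units; beyond the scatter), and no measured step in this assay shows a gain. Compound 4 is therefore expected to sit at or near the limit, estimated at 100000 nM (range 15000 nM to 500000 nM), an expected step of a number no higher from compound 3 to compound 4 (the limit leaves the size open).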

Compound 4, half-maximal inhibitory concentration: 45000 nM
The estimate for compound 4 lay 2.2-fold (0.35 log units) above the measured number, within the range that was stated.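

In this assay carbamoyl on this aromatic carbon gives the first gain seen at the position, with an at least 2.2-fold lower number from compound 3 to compound 4 (0.34 log units; beyond the scatter) and an at least 2.2-fold lower number from compound 2 to compound 4 (0.34 log units; beyond the scatter) showing that a smaller group here need not lose activity. Both of these steps rest on limits and not on numbers: the limit of > 100000 nM in this assay, at which 2 of the 4 values shown sit. Carbamoyl still does not match the group on compound 1, with a 5.0-fold higher number from compound 1 to compound 4 (0.70 log units; beyond the scatter) marking a modest loss.

As far as these compounds go, whether an amine, a carboxylic acid or a nitrile on this carbon would come closer to compound 1 remains open. So does the effect of a longer chain on the carbonyl carbon of compound 1.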